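The source may hold more compounds than are shown below. What is called first, only, known or untested is meant among the compounds shown, and "the series" means these compounds.

Compound 3 `CCc1ccccc1-n1nncc1CN1C(=O)C2(C(C#N)=C(N)Oc3c(N)cc4nc5ccccc5nc4c32)c2ccccc21` is the only one of the three measured compounds to give a number in a functional assay on MCF7 cells (Homo sapiens) for antiproliferative activity, read by MTT assay, with a stated time of 48 h (a higher number here means a weaker inhibitor, a lower number a stronger inhibitor), where compound 3 gives 24600 nM. Compound 1 `N#CC1=C(N)Oc2c(c3nc4ccccc4nc3c3ccccc23)C12C(=O)N(Cc1cnnn1-c1ccccc1Br)c1ccccc12` reaches the limit of the assay, > 50000 nM. Compound 2 `N#CC1=C(N)Oc2c(c3nc4ccccc4nc3c3ccccc23)C12C(=O)N(Cc1cnnn1-c1cc(Cl)ccc1Cl)c1ccccc12` likewise gives a limit, > 50000 nM. The step that the two limits leave unreadable from compound 1 to compound 2 therefore cannot be read, and the limit of > 50000 nM in this assay, at which 2 of the 3 values shown sit, shows where those two values sit. Compound 4 `COc1ccccc1-n1nncc1CN1C(=O)C2(C(C#N)=C(N)Oc3c(N)cc4nc5ccccc5nc4c32)c2ccccc21` differs from compound 3 by methoxy in place of ethyl on an aromatic carbon. Within the data shown here, no measured step touches this change, so no shift beyond the usual scatter is expected, and the estimate for compound 4 is 25000 nM with a range from 8000 nM to 60000 nM. This amounts to an expected step of a 1.0-fold higher number from compound 3 to compound 4 (0.01 log units; within the scatter).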

Compound 4, half-maximal inhibitory concentration: 28900 nM
Beside the measured number, compound 4's estimate is 1.2-fold (0.06 log units) below it; measured number inside the range.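

In this assay, replacing 2-ethylphenyl with 2-methoxyphenyl gives a 1.2-fold higher number from compound 3 to compound 4 (0.07 log units; within the scatter), so at this place, ortho to a large group, an added hydrogen-bond acceptor leaves the number unmoved. Among these compounds, this is the first step with a number at both ends, as the earlier step between compound 1 and compound 2 cannot be read. Nothing shown accounts for this likeness.

Going by these compounds, whether an amine, a carboxylic acid or a longer chain at this place would move the number beyond the scatter stays open. So does whether this swap reads the same on the core of compound 1.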